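Working notes: dichlorophenyl for pyridinyl on the ring nitrogen

A few compounds are considered here, and "the series" means these few. Any claim that something is new, unique, unknown or untested is made for them only; others in the source may bear on it.

Measured so far:
Compound 1 `CCN1CCN(C(=S)SCC(O)Cn2c([N+](=O)[O-])cnc2C)CC1`: in a toxicity assay on HeLa cells (Homo sapiens) for cytotoxicity, read by MTT assay, with a stated time of 24 h (on this read-out lower numbers stand for stronger inhibition and higher numbers for weaker inhibition), compound 1 sits at the limit > 5000000 nM and gives no number.
Compound 2 `CCOC(=O)N1CCN(CC(O)Cn2c([N+](=O)[O-])cnc2C)CC1`: in this assay compound 2 gives 3670000 nM.
Compound 3 `Cc1ncc([N+](=O)[O-])n1CC(O)CN1CCN(c2ccccn2)CC1`: in this assay compound 3 gives 1830000 nM.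

Compound 3 holds the lowest of the two numbers shown; the nearest is compound 2, and the two lie within the scatter of each other. Compound 4 `Cc1ncc([N+](=O)[O-])n1CC(O)CN1CCN(c2cccc(Cl)c2Cl)CC1` differs from compound 3 by 2,3-dichlorophenyl in place of pyridin-2-yl on an amine nitrogen in a ring. For the measured compounds named here, the only measured step, a 2.0-fold lower number from compound 2 to compound 3 (0.30 log units; within the scatter), also swaps the group on this ring nitrogen and stayed within the scatter, so it gives no ground for a step beyond the scatter in this assay here, in either direction. Compound 4 is therefore expected near compound 3, with the estimate 1500000 nM and a range of 500000 nM to 4500000 nM. The expected step is a 1.2-fold lower number from compound 3 to compound 4 (0.09 log units; within the scatter).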

Compound 4, half-maximal inhibitory concentration: > 5000000 nM
Compound 4 was reported as a limit (the forecaster's own chance of this, stated with the estimate: 10%); at least 3.3-fold (0.52 log units) between middle value and limit.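

In this assay the group on this ring nitrogen can move the read-out beyond the scatter: an at least 2.7-fold higher number from compound 3 to compound 4 (0.43 log units; beyond the scatter), whereas the earlier swap at this place stayed within it: a 2.0-fold lower number from compound 2 to compound 3 (0.30 log units; within the scatter). Against compound 2 the floor is small, an at least 1.3-fold higher number from compound 2 to compound 4 (0.13 log units; that floor lies within the scatter), so no order can be read for that pair. Compound 4 gives > 5000000 nM, which is a limit and not a number, and it is the same limit seen elsewhere in the series: the limit of > 5000000 nM in this assay, at which 2 of the 4 values shown sit.

Going by these compounds, the true size of the step remains open, as does whether it follows the loss of the pyridin-2-yl ring nitrogen or the entry of the two chlorine atoms. An unsubstituted phenyl on this ring nitrogen would separate those two changes.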